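The source may hold more compounds than are shown below. What is called first, only, known or untested is meant among the compounds shown, and "the series" means these compounds.

In an assay on nucleic acid for inhibition of Nucleic Acid, read by fluorescence, tested at 100 uM (a higher number here means more inhibition at the concentration tested (going by the name of the read-out), a lower number less inhibition), compound 1 `CN(CCCc1ccccc1)Cc1cn(CC(O)COC(=O)NCc2ccccc2)nn1` gives 79%, while compound 2 `CN(CCCc1ccccc1)Cc1cn(CC(O)COC(=O)c2ccccc2)nn1` gives 12%. Within the data shown here, the only change between them, (phenyl in place of benzylamino on a carbonyl carbon), made the step of a number 67 percentage points lower from compound 1 to compound 2 (beyond the scatter). Compound 3 `CCOC(=O)C1CCCN(Cc2cn(CC(O)COC(=O)NCc3ccccc3)nn2)C1` gives 47% in this assay; the difference between its core and the core of compound 1 is not broken down here. Compound 4 `CCOC(=O)C1CCCN(Cc2cn(CC(O)COC(=O)c3ccccc3)nn2)C1` carries the same change against compound 3, (phenyl in place of benzylamino on a carbonyl carbon), at a place described in the same words. A large downward step is expected again, of the same kind as the earlier one, resting on the step of a number 67 percentage points lower from compound 1 to compound 2 (beyond the scatter) shown by compound 1; since compound 3 starts from 47%, less room remains to fall. The expected step is a number 39 percentage points lower from compound 3 to compound 4 (beyond the scatter). Compound 4 is estimated at 8% in this assay, within -10% to 28%.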

Compound 4, a percentage reported as inhibition, at one concentration (the size of the read-out at that concentration, not a potency): 6%
Beside the measured number, compound 4's estimate is 2 percentage points above it, and the stated range covers the measured number.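

In this assay the change from benzylamino to phenyl on a carbonyl carbon lowers the number on both cores, and on the second core the result is a number 41 percentage points lower from compound 3 to compound 4 (beyond the scatter), so the direction carries over between the two cores shown. The size does not carry over: the same change on two cores in this assay, a number 67 percentage points lower (beyond the scatter) from compound 1 to compound 2 and a number 41 percentage points lower (beyond the scatter) from compound 3 to compound 4, 26 percentage points apart, beyond the scatter of two such steps. The steps start from different values, with compound 1 at 79% and compound 3 at 47%, and two cores cannot show how the change behaves on any other core or which part of benzylamino matters.

Still open, on these data alone, is how other groups on the same carbonyl carbon compare with benzylamino, such as anilino, phenethylamino with its longer chain, or benzyloxy, which has oxygen in place of the amine nitrogen.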